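The source may hold more compounds than are shown below. What is called first, only, known or untested is meant among the compounds shown, and "the series" means these compounds.

For the measured compounds named here, in a functional assay on ZR-75-1 cells (Homo sapiens) for cytotoxicity, read by MTT assay, with a stated time of 68 h (a higher number here means a weaker inhibitor, a lower number a stronger inhibitor), compound 1 `O=C(/C=C/c1cccc(OCc2ccccc2)c1)c1ccc(Br)cc1` gives 6500 nM as the lower of the two numbers so far, and compound 2 `Cc1ccc(C(=O)/C=C/c2cccc(OCc3ccccc3)c2)cc1` gives 25800 nM as the higher. Compound 3 `COc1ccc(C(=O)/C=C/c2cccc(OCc3ccccc3)c2)cc1` is still unmeasured and carries methoxy in place of bromo on an aromatic carbon, para to a large group (methoxy in place of bromo on an aromatic carbon). Going by the values given here, the one measured step at that place, methyl in place of bromo (a 4.0-fold higher number from compound 1 to compound 2 (0.60 log units; beyond the scatter)), is modest but beyond the scatter, so a rise of similar or smaller size is expected in this assay for compound 3. Compound 3 is expected at 15000 nM within an estimated range of 5000 nM to 40000 nM overall. This expected change amounts to a 2.3-fold higher number from compound 1 to compound 3 (0.36 log units; beyond the scatter) in all.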

Compound 3, half-maximal inhibitory concentration: 19900 nM
Beside the measured number, compound 3's estimate is 1.3-fold (0.12 log units) below it; the measured number falls inside the stated range.
By their numbers in this assay, from the lowest: compound 1; then compounds 3 and 2 (each within the scatter of the next).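

In this assay, the bromo position now has a second replacement, and methoxy also gives a higher number than bromo (a 3.1-fold higher number from compound 1 to compound 3 (0.49 log units; beyond the scatter)), so the rise seen with methyl is not confined to that one group. Methoxy and methyl cannot be told apart at this place (a 1.3-fold lower number from compound 2 to compound 3 (0.11 log units; within the scatter)). No measured evidence at hand bears on why replacing bromo has this effect. The compounds shown leave open whether chloro or fluoro would match bromo in compound 1, and how an amine or a carboxylic acid would read at this place.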